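The source may hold more compounds than are shown below. What is called first, only, known or untested is meant among the compounds shown, and "the series" means these compounds.

Compound 1 `O=C(CCN1CCN(c2ccc(Cl)cc2)CC1)c1ccc(F)c(Br)c1` was tested in an ADME assay on Vero cells (Chlorocebus sabaeus) for cytotoxicity, read by resazurin assay, with a stated time of 72 h (on this read-out lower numbers stand for stronger inhibition and higher numbers for weaker inhibition), where compound 1 gives 206000 nM. Compound 2 `O=C(CCN1CCN(c2ccc([N+](=O)[O-])cc2)CC1)c1ccc(F)c(Br)c1` differs from it by one change, (nitro in place of chloro on an aromatic carbon), and in this assay compound 2 gives 256000 nM; the step is a 1.2-fold higher number from compound 1 to compound 2 (0.09 log units; within the scatter). Compound 3 `O=C(CCN1CCN(c2ccc(Cl)cc2)CC1)c1ccc(C(F)(F)F)cc1` carries a different core; how its core differs from that of compound 1 is not broken down here. In this assay compound 3 gives 54200 nM. Compound 4 `O=C(CCN1CCN(c2ccc([N+](=O)[O-])cc2)CC1)c1ccc(C(F)(F)F)cc1` has not yet been measured. Going by the values given here, it differs from compound 3 by nitro in place of chloro on an aromatic carbon, the same change, at the same place, as the one between compound 1 and compound 2. Resting on the earlier step of a 1.2-fold higher number from compound 1 to compound 2 (0.09 log units; within the scatter), compound 4 is expected to lie at a step of a 1.2-fold higher number from compound 3 to compound 4 (0.08 log units; within the scatter). For compound 4 the estimated value is 65000 nM, with an expected range from 30000 nM to 140000 nM.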

Compound 4, half-maximal inhibitory concentration: 75700 nM
For compound 4 the middle estimate is 1.2-fold (0.07 log units) below the measured one, within the range that was stated.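

In this assay, putting nitro in place of chloro on the second core gives a 1.4-fold higher number from compound 3 to compound 4 (0.15 log units; within the scatter), so this swap again produces no step beyond the usual scatter. Set beside the earlier step, the swap behaves alike on the two cores: the same change on two cores in this assay, a 1.2-fold higher number (0.09 log units; within the scatter) from compound 1 to compound 2 and a 1.4-fold higher number (0.15 log units; within the scatter) from compound 3 to compound 4, 1.1-fold (0.05 log units) apart, within the scatter of two such steps. This shows agreement on these two cores in this one assay only; two cores are too few to show that the swap will stay this small on other cores, and the steps do not explain why it is small.

The compounds shown carry only chloro or nitro at this place, so an amine, a carboxylic acid or a nitrile there remains open. Also open, going by these compounds, is how the swap behaves on a core with a longer chain.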